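The source may hold more compounds than are shown below. What is called first, only, known or untested is meant among the compounds shown, and "the series" means these compounds.

Measured so far in a functional assay on DU-145 cells (Homo sapiens) for inhibition, read by trypan blue exclusion, with a stated time of 96 h; a lower number here means a stronger inhibitor of growth, a higher number a weaker inhibitor of growth:

compound 1 `Cc1ccsc1/C=C(/SCc1ccc(Cl)cc1)C(=O)c1ccc(Cl)cc1` gives 50000 nM
compound 2 `Cc1ccsc1/C=C(/SCc1ccc(Cl)cc1Cl)C(=O)c1ccc(Cl)cc1` gives 10000 nM
compound 3 `O=C(/C(=C\c1cccc(Cl)c1Cl)SCc1ccc(Cl)cc1)c1ccc(Br)cc1` gives 10000 nM

Compound 2 differs from compound 1 by chloro in place of hydrogen on an aromatic carbon and that change gave a 5.0-fold lower number from compound 1 to compound 2 (0.70 log units; beyond the scatter), a step beyond the usual scatter. Compound 3 sits level with compound 2 at the digits given, so the two are within the scatter of each other; compound 3 stands a clear step away from compound 1 in the same direction as compound 2. The difference between the core of compound 3 and the core of compound 1 is not broken down here.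

Compound 4 `O=C(/C(=C\c1cc(Cl)cc(Cl)c1Cl)SCc1ccc(Cl)cc1)c1ccc(Br)cc1` differs from compound 3 by chloro in place of hydrogen on an aromatic carbon. This is the same kind of change as that from compound 1 to compound 2, but not the same: in compound 2 the chloro enters ortho to a large group and meta to a chloro group, whereas in compound 4 it enters meta to a chloro group, meta to a large group and para to a chloro group, and the surrounding core is another one.

Going by the values given here, the only guide is the single step from compound 1 to compound 2, a 5.0-fold lower number from compound 1 to compound 2 (0.70 log units; beyond the scatter), made on a different core and at a different place. The step from compound 3 to compound 4 in this assay is therefore expected to be smaller, at about a 2.0-fold lower number from compound 3 to compound 4 (0.30 log units; within the scatter). Compound 4 is expected to give about 5000 nM, most likely between 1500 nM and 15000 nM.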

Compound 4, concentration for 50% growth inhibition: 1000 nM
Compound 4: middle estimate off by 5.0-fold (0.70 log units), on the high side; the measured number lies below the stated range.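

In this assay, chloro in place of hydrogen on an aromatic carbon gave a 10-fold lower number from compound 3 to compound 4 (1.00 log units; beyond the scatter), and this step agrees with the earlier one: the same change on two cores in this assay, a 5.0-fold lower number (0.70 log units; beyond the scatter) from compound 1 to compound 2 and a 10-fold lower number (1.00 log units; beyond the scatter) from compound 3 to compound 4, 2.0-fold (0.30 log units) apart, within the scatter of two such steps

Within these two pairs, the change therefore carries from one core to the other in both direction and approximate size, even though the chloro enters at a different place in each pair. Going by these compounds alone, this rests on only two steps. Core and place differ together in these pairs, and the pairs cannot separate the influence of one from the other. Nor do they show that the step would hold on a further core or at another aromatic carbon.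

Still open, from the compounds shown here alone, is whether chloro entering at the same place on both cores would give matching steps, and whether a further chloro on compound 4 would lower the number again. Going by these compounds, it is also open whether the step belongs to chloro in particular or would be matched by a methoxy group, an amine or a carboxylic acid on the same aromatic carbon of the 2,3-dichlorophenyl group of compound 3.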